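The compounds below may be only part of what the source reports. "The series", "measured", "known", "first", "only" and "open" are said of these compounds alone.

Of the compounds shown here, three sharing one core have been tested in an assay on isolated protein for inhibition of aldehyde dehydrogenase 1A1 (Homo sapiens), read by spectrophotometry, tested at 10 uM; on this read-out higher numbers stand for more inhibition at the one concentration tested (going by the name of the read-out) and lower numbers for less inhibition. Compound 1 `Cc1cccc(Cn2c(CN3CCN(C(=O)c4ccc([N+](=O)[O-])cc4)CC3)nc3ccccc32)c1` gives 24.3% in this assay, the largest of the three numbers. Compound 3 `CCn1c(CN2CCN(C(=O)C3CC3)CC2)nc2ccccc21` gives 20.8%, a value that sits within the usual scatter of that of compound 1, so the two cannot be told apart. Compound 2 `CC(C)Cn1c(CN2CCN(C(=O)C3CC3)CC2)nc2ccccc21` gives 13.1%, and its gap to compound 1 lies beyond the scatter. Among the compounds with values here, the only step measured between two compounds that differ in a single place runs a number 7.7 percentage points higher from compound 2 to compound 3 (within the scatter); it concerns the group on a saturated chain carbon bound to an aromatic nitrogen, not the part of the molecule that is altered here.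

Compound 4 `CCc1ccc(C(=O)N2CCN(Cc3nc4ccccc4n3Cc3cccc(C)c3)CC2)cc1` differs from compound 1 in one place: ethyl in place of nitro on an aromatic carbon. Within the data shown here, no measured step touches this position or this kind of swap, so there is no basis for expecting a shift in either direction, and the only guide is that the single change seen so far stayed within the scatter. Compound 4 is therefore expected to give 22% in this assay, with a range from 8% to 38%. The step of a number 2.3 percentage points lower from compound 1 to compound 4 (within the scatter) is estimated to lie within the scatter.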

Compound 4, a percentage reported as inhibition, at one concentration (the size of the read-out at that concentration, not a potency): 67%
Beside the measured number, compound 4's estimate is 45 percentage points below it; measured number above the stated range.
By their numbers in this assay, from the lowest: compounds 2, 3 and 1 (each within the scatter of the next, the first and the last beyond it); then compound 4.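

In this assay, replacing the 4-nitrophenyl group with 4-ethylphenyl gives a number 42.7 percentage points higher from compound 1 to compound 4 (beyond the scatter), so a single group on this aromatic carbon, para to a large group, can strongly change the reading. Of the two single-place steps shown, only this one lies beyond the scatter, whereas a number 7.7 percentage points higher from compound 2 to compound 3 (within the scatter), at a different part of the molecule. The swap removes the nitrogen, the oxygens and the hydrogen-bond acceptors of nitro and brings in a chain of two carbons, but nothing measured here shows which of these differences matters.

As far as these compounds go, with only nitro and ethyl at this position, it remains open whether the higher number comes from losing nitro or from gaining ethyl, and a compound carrying plain hydrogen, methyl, a longer chain, methoxy or an amine there would help to separate the two. From the compounds shown here alone, it is also open whether the step would hold with a different group on the aromatic nitrogen of the shared core, and how the reading at one concentration relates to potency.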